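A few compounds are considered here, and "the series" means these few. Any claim that something is new, unique, unknown or untested is made for them only; others in the source may bear on it.

Measured in a physicochemical assay for lipophilicity, using the shake flask method, in phosphate buffer, measured as octanol-water partition, with a stated time of 30 min, at pH 7.4; a lower number here means a more polar compound, a higher number a more lipophilic compound:
- compound 1 `Cn1nccc1-c1cnc(NCc2c(F)ccc3c2CCO3)c2cn[nH]c(=O)c12`: 2.6
- compound 2 `C[C@@H]1CC(=O)N(c2cnc(NCc3c(F)ccc4c3CCO4)n3cnnc23)C1`: 1.8

Of these two numbers, compound 1 has the higher value at 2.6, while compound 2 gives 1.8. That gap is beyond the usual scatter of repeat measurements. The two compounds differ in more than one place, however, so the gap says nothing about any single structural change.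

Compound 3 `Cc1nc(CN(C)C)ccc1-c1cnc(NCc2c(F)ccc3c2CCO3)c2cn[nH]c(=O)c12` keeps the core of compound 1 and alters one group: 6-((dimethylamino)methyl)-2-methylpyridin-3-yl in place of 1-methyl-1H-pyrazol-5-yl on an aromatic carbon. Here 6-((dimethylamino)methyl)-2-methylpyridin-3-yl takes the place of 1-methyl-1H-pyrazol-5-yl on an aromatic carbon of a six-membered aromatic ring with 1 nitrogen, part of a fused or bridged system of two rings.

For the measured compounds named here, no measured pair isolates a change of this kind, so the expectation in this assay rests on the structural change alone and remains uncertain. A moderate fall is expected, estimated as a number 0.50 log units lower from compound 1 to compound 3 (beyond the scatter). For compound 3 the estimated value is 2.1, with an expected range from 1.5 to 2.6.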

Compound 3, distribution coefficient: 2
The estimate for compound 3 lay 0.10 log units above the measured number; the range from low to high includes it.
By their numbers in this assay, from the lowest: compounds 2 and 3 (each within the scatter of the next); then compound 1.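

For the compounds shown here, the swap of 1-methyl-1H-pyrazol-5-yl for 6-((dimethylamino)methyl)-2-methylpyridin-3-yl gives the first clean one-place comparison in this assay, and the result is a number 0.60 log units lower from compound 1 to compound 3 (beyond the scatter). This shows that the number responds to the group on this aromatic carbon of the shared core, and it moves downward even though the entering group has 11 heavy atoms against 6 for the one that leaves, with the same counts of hydrogen-bond donors and acceptors, so in this pair a larger heavy-atom count does not go with a higher number. No measurement shown here explains why the number falls.

The change replaces a five-membered aromatic ring with a six-membered one and also brings in the methyl and dimethylaminomethyl groups, so this single step cannot divide the fall among those parts. Going by these compounds, it also remains open how the number would respond at this position to a different group, such as a morpholine ring or a carboxylic acid, or to a longer chain carrying the same dimethylamino end.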